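Bromo substitution on the aryl ring: working notes

The source may report more compounds than this note shows. Statements on the series, on what has been measured and on what is new or still open speak of the compounds shown alone.

Measured compounds:
compound 1, `Cn1nnnc1SCC(=O)N/N=C/c1ccccc1` — in an ADME assay on NIH3T3 cells (Mus musculus) for cytotoxicity, read by XTT assay, with a stated time of 24 h (a higher number here means a weaker inhibitor, a lower number a stronger inhibitor), compound 1 gives 9700000 nM
compound 2, `Cn1nnnc1SCC(=O)N/N=C/c1ccccc1Br` — in this assay compound 2 gives 20000 nM

Among the measured compounds shown here, compound 1 stands highest of the two numbers so far in this assay; its nearest neighbour is compound 2, reached by a 490-fold lower number from compound 1 to compound 2 (2.69 log units; beyond the scatter). For the measured compounds named here, that single step, bromo in place of hydrogen on an aromatic carbon, is the only comparison available.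

Compound 3, `Cn1nnnc1SCC(=O)N/N=C/c1cccc(Br)c1`, is not yet measured. Against compound 1 the change is bromo in place of hydrogen on an aromatic carbon. Going by the values given here, the bromo atom is the same as in compound 2, but it sits at a different carbon of the ring, so the one measured step bears on it only in part. Among the compounds with values here, no measured pair shows what moving the bromo group around the ring does, so the expected size is uncertain.

Taking the step from compound 1 to compound 2 as the guide while allowing for the changed position, compound 3 is expected to give a lower number, a step of about a 65-fold lower number from compound 1 to compound 3 (1.81 log units; beyond the scatter). The estimate for compound 3 in this assay is 150000 nM, with a range from 20000 nM to 2000000 nM.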

Compound 3, half-maximal inhibitory concentration: 316000 nM
Estimate against measurement, compound 3: 2.1-fold (0.32 log units) below, within the range that was stated.
By their numbers in this assay, from the lowest: compound 2; then compound 3; then compound 1.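

In this assay, bromo in place of hydrogen on an aromatic carbon, here meta to a large group, again lowers the number, with a 31-fold lower number from compound 1 to compound 3 (1.49 log units; beyond the scatter) as the step, so among the compounds shown the lowering is not tied to a single carbon of the ring. Position still matters to the size of the effect: the earlier step is a 490-fold lower number from compound 1 to compound 2 (2.69 log units; beyond the scatter) and leaves compound 2 at 20000 nM, whereas compound 3 stands at 316000 nM and so keeps a higher number than compound 2 despite carrying the same bromo group. No measurement bears on why the bromo group lowers the number or why the two placements give different values.

The compounds shown leave open whether the lowering belongs to bromo specifically or would also follow from another group on the ring, such as chloro, methoxy, an amine or a carboxylic acid. They also leave open what bromo does at the remaining ring carbons, and whether two bromo groups on the same ring would lower the number further.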